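A few compounds are considered here, and "the series" means these few. Any claim that something is new, unique, unknown or untested is made for them only; others in the source may bear on it.

Measured compounds in a functional assay on THP-1 cells (Homo sapiens) for inhibition, read by ELISA, with stated times of 30 min and 24 h, tested at 1 uM; a higher number here means a stronger effect of the compound at the concentration tested, a lower number a weaker effect:
- compound 1 `COc1cc(O)c(C(=O)c2cccc(F)c2)c(OC)c1`, giving 38%
- compound 2 `COc1cc(O)c(C(=O)c2ccccc2Br)c(OC)c1`, giving 7%
- compound 3 `COc1cc(OC)c(C(=O)c2cccc(F)c2)c(O)c1CN1CCCCC1`, giving 30%

Compound 2 holds the lowest of the three numbers. The nearest number is that of compound 3, which lies above compound 2 by a gap beyond the scatter; the furthest is that of compound 1, also above compound 2 and also beyond the scatter. Among the compounds with values here, compound 2 is thus the weakest of the three in this assay on the numbers so far.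

The compound to be measured next is compound 4 `COc1cc(OC)c(C(=O)c2ccccc2Br)c(O)c1CN1CCCC1`. It differs from compound 2 in one place: (pyrrolidin-1-yl)methyl in place of hydrogen on an aromatic carbon.

Within the data shown here, one measured step bears on this change: the analogous addition of a ring-bearing methyl group on the same aromatic carbon of the shared core, going from compound 1 to compound 3, gave a number 8 percentage points lower from compound 1 to compound 3 (within the scatter). That step stayed within the scatter. Nothing in the set suggests that the five-membered ring should behave differently from the six-membered one, so for the step from compound 2 to compound 4 in this assay no change beyond the scatter is expected, in either direction.

Compound 4 is therefore estimated at 10%, with a range from 0% to 25%. This estimate means an expected step of a number 3 percentage points higher from compound 2 to compound 4 (within the scatter), which would sit within the scatter.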

Compound 4, a percentage reported as activity, at one concentration (the size of the read-out at that concentration, not a potency): 19%
Compound 4: the middle estimate sits 9 percentage points below what was measured; the range from low to high includes it.
By their numbers in this assay, from the lowest: compound 2; then compound 4; then compounds 3 and 1 (each within the scatter of the next).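

In this assay, (pyrrolidin-1-yl)methyl in place of hydrogen gives a number 12 percentage points higher from compound 2 to compound 4 (beyond the scatter), so this aromatic carbon, ortho to a hydroxy group and para to a methoxy group, can take a group of this size with a modest gain in the read-out. The earlier change at the same carbon, (piperidin-1-yl)methyl in place of hydrogen, gave a number 8 percentage points lower from compound 1 to compound 3 (within the scatter), so substitution here is not neutral in every case, though the two steps differ both in the entering ring and in the rest of the molecule, and the shown pairs cannot assign the contrast to either. No measurement available here accounts for the gain or for the contrast between the two steps.

The compounds shown leave open whether the contrast follows the five-membered versus six-membered ring or the bromine versus fluorine substituent on the other aromatic ring, as no pair varies only one of these. Also open, from the compounds shown here alone, is how an open-chain amine such as dimethylaminomethyl, or a morpholin-4-ylmethyl group, would behave at this carbon.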